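The source may hold more compounds than are shown below. What is called first, only, known or untested is meant among the compounds shown, and "the series" means these compounds.

Measured compounds:
compound 1 `CN1CCC(Oc2ccc(Nc3ncc4nc([S+]([O-])c5ccccc5)n(C5CCOCC5)c4n3)cc2)CC1` — 853 nM
compound 2 `CN1CCN(c2ccc(Nc3ncc4nc([S+]([O-])Cc5ccccc5)n(C5CCOCC5)c4n3)cc2)CC1` — 433 nM
compound 3 `CN(C)C1CCN(c2ccc(Nc3ncc4nc([S+]([O-])c5ccccc5)n(C5CCOCC5)c4n3)cc2)CC1` — 1290 nM

All three were tested in a functional assay on HCC827 cells (Homo sapiens) for antiproliferative activity, read by MTT assay, with a stated time of 72 h; on this read-out lower numbers stand for stronger inhibition and higher numbers for weaker inhibition. Of the three numbers, compound 2 gives the lowest. Compound 1 stands nearest to it, and that gap lies within the usual scatter, so the two cannot be separated with confidence; compound 3 stands furthest away, and that gap is beyond the scatter. Within the data shown here, the only single-point step among the measured compounds, a 1.5-fold higher number from compound 1 to compound 3 (0.18 log units; within the scatter), concerns a different part of the molecule and is itself within the scatter.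

Compound 4, `CN1CCN(c2ccc(Nc3ncc4nc(Sc5ccccc5)n(C5CCOCC5)c4n3)cc2)CC1`, has not yet been measured. It differs from compound 2 in one place: a group of 7 heavy atoms (6 carbon, 1 sulfur; one six-membered aromatic ring of carbon only) in place of a group of 9 heavy atoms (7 carbon, 1 oxygen, 1 sulfur; one six-membered aromatic ring of carbon only), on an aromatic carbon. Among the measured compounds shown here, no measured step touches this part of the molecule, so the measured data give no direction for the change. With nothing to point either way, no step beyond the scatter is expected. The value of compound 4 in this assay is estimated at 450 nM, with a range from 150 nM to 1400 nM. The expected step is a 1.0-fold higher number from compound 2 to compound 4 (0.02 log units; within the scatter), which is taken to sit within the scatter.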

Compound 4, half-maximal inhibitory concentration: 42.6 nM
Compound 4: the middle estimate sits 11-fold (1.02 log units) above what was measured; measured number below the stated range.
By their numbers in this assay, from the lowest: compound 4; then compounds 2, 1 and 3 (each within the scatter of the next, the first and the last beyond it).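

In this assay, the aromatic carbon between two ring nitrogen atoms proves highly sensitive to what it carries: replacing the group of 9 heavy atoms with phenylsulfanyl gives a 10-fold lower number from compound 2 to compound 4 (1.01 log units; beyond the scatter). Among these compounds, this is the first step at this position, and it far exceeds the only earlier step, a 1.5-fold higher number from compound 1 to compound 3 (0.18 log units; within the scatter), which concerned a different part of the molecule. No measurement here explains the size of this change.

The entering group has no oxygen and fewer carbons than the one it replaces, so the compounds shown cannot tell which of these differences matters. Benzylsulfanyl would separate the two, while phenoxy or an amine at this carbon would test whether sulfur is needed at all.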